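Swapping a Thiophene for an Amide: Compound 2 to Compound 3

A few compounds are considered here, and "the series" means these few. Any claim that something is new, unique, unknown or untested is made for them only; others in the source may bear on it.

Compound 1 `CNC(=O)CN1CCC(c2cc3c(-c4ccc(=O)n(C(C)C)c4)ccnc3[nH]2)CC1`: 1.7 uL/min
Compound 2 `CC(C)n1cc(-c2ccnc3[nH]c(C4CCN(Cc5cccs5)CC4)cc23)ccc1=O`: 5.8 uL/min

In an ADME assay on cells (Hepatocyte, Homo sapiens) for metabolic stability (on this read-out higher numbers stand for fast clearance and lower numbers for slow clearance), compound 2 gives the higher of the two numbers, and the gap to compound 1 is told by a 3.4-fold higher number from compound 1 to compound 2 (0.53 log units; beyond the scatter). Compound 3 `CC(C)n1cc(-c2ccnc3[nH]c(C4CCN(CC(=O)N(C)C)CC4)cc23)ccc1=O` differs from compound 2 by dimethylcarbamoyl in place of thiophen-2-yl on a saturated chain carbon bound to an amine nitrogen in a ring. Within the data shown here, only that one measured step bears on this change, and it ran the other way, from methylcarbamoyl to thiophen-2-yl. Since compound 3 carries dimethylcarbamoyl, close kin to the methylcarbamoyl of compound 1, the number for compound 3 is expected to fall from compound 2, about a 2.5-fold lower number from compound 2 to compound 3 (0.40 log units; beyond the scatter). Compound 3 is estimated at 2.3 uL/min, within 1 uL/min to 5 uL/min.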

Compound 3, intrinsic clearance in a liver preparation (reported as CLH), per the amount of preparation that the assay uses in the Hepatocyte assay: < 1 uL/min
Compound 3: only a limit was reported (the forecaster's own chance of this, stated with the estimate: 5%); middle value at least 2.3-fold (0.36 log units) away from the limit.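

In the Hepatocyte assay the change from thiophen-2-yl to dimethylcarbamoyl gives an at least 5.8-fold lower number from compound 2 to compound 3 (0.76 log units; beyond the scatter), so the carbamoyl side again reads lower at this place, while methyl in place of hydrogen on the amide-type nitrogen gives an at least 1.7-fold lower number from compound 1 to compound 3 (0.23 log units; that floor lies within the scatter), which settles no order. The number for compound 3 is a limit of the assay. In a physicochemical assay for acid dissociation, compound 2 gives 6.5 and compound 3 gives 7.9, which is a number 1.40 log units higher from compound 2 to compound 3 (beyond the scatter).

From the compounds shown here alone, whether this second shift has any tie to the clearance numbers stays open. Going by these compounds, how a carboxylic acid or a longer chain would read at this place also stays open.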